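Benzamide variation on a shared quinazoline-free core series

A few compounds are considered here, and "the series" means these few. Any claim that something is new, unique, unknown or untested is made for them only; others in the source may bear on it.

Measured compounds:
- compound 1, `COc1cc2ncnc(Nc3ccc(NC(=O)c4cccc(C)c4)cc3)c2cc1OC`: 7500 nM
- compound 2, `COc1cc2ncnc(Nc3ccc(NC(=O)c4cccc(F)c4)cc3)c2cc1OC`: 8200 nM
- compound 3, `COc1cc2ncnc(Nc3ccc(NC(=O)c4ccc(Br)cc4)cc3)c2cc1OC`: 35000 nM

In a functional assay on HepG2 cells (Homo sapiens) for inhibition, read by MTT assay (on this read-out higher numbers stand for weaker inhibition and lower numbers for stronger inhibition), compound 1 gives the lowest of the three numbers. Compound 2 sits nearest to it, the step of a 1.1-fold higher number from compound 1 to compound 2 (0.04 log units; within the scatter) lying within the scatter, so no order between compound 1 and compound 2 can be read. Compound 3 sits furthest away, the step of a 4.7-fold higher number from compound 1 to compound 3 (0.67 log units; beyond the scatter) being modest but beyond the scatter; the step of a 4.3-fold higher number from compound 2 to compound 3 (0.63 log units; beyond the scatter) points the same way.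

Compound 4, `COc1cc2ncnc(Nc3ccc(NC(=O)c4ccc(I)cc4)cc3)c2cc1OC`, has not yet been measured in this assay. It differs from compound 1 in one place: 4-iodophenyl in place of 3-methylphenyl on a carbonyl carbon.

For the measured compounds named here, the step that bears on this change is the one to compound 3, where a 4-bromophenyl likewise replaced the 3-methylphenyl on the carbonyl carbon and gave a 4.7-fold higher number from compound 1 to compound 3 (0.67 log units; beyond the scatter). Going by the values given here, a 4-iodophenyl is the closest analogue of that change among the measured compounds, so a step of similar size and in the same direction is expected for compound 4, namely a 4.7-fold higher number from compound 1 to compound 4 (0.67 log units; beyond the scatter), with a wide margin since only one such step is known.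

Compound 4 is therefore estimated to give 35000 nM in this assay, within a range of 12000 nM to 100000 nM.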

Compound 4, half-maximal inhibitory concentration: 40000 nM
Compound 4: the middle estimate sits 1.1-fold (0.06 log units) below what was measured; measured number inside the range.
By their numbers in this assay, from the lowest: compounds 1 and 2 (each within the scatter of the next); then compounds 3 and 4 (each within the scatter of the next).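

In this assay, iodo in place of bromo on an aromatic carbon gives a 1.1-fold higher number from compound 3 to compound 4 (0.06 log units; within the scatter) and so leaves no order between the two 4-halophenyl amides, which means that a change of halogen at this place does not separate them on this read-out. The 4-bromophenyl result no longer stands alone: the steps of a 5.3-fold higher number from compound 1 to compound 4 (0.73 log units; beyond the scatter) and a 4.9-fold higher number from compound 2 to compound 4 (0.69 log units; beyond the scatter) run the same way as the steps to compound 3, and none of the four compounds goes against this. Within these four compounds, the higher numbers therefore go with both 4-halophenyl groups on the carbonyl carbon, rather than with the bromine of compound 3 alone.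

Each of these steps changes the group on the phenyl ring and its place together, so a 3-bromophenyl and a 4-methylphenyl on the same carbonyl carbon would be needed to tell those two changes apart, while a 4-aminophenyl or a 4-carboxyphenyl would show whether the trend holds beyond halogens. Nothing available explains why the 4-halophenyl compounds give the higher numbers in this series.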